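This account rests on a few compounds, and the source may have more. Where it says the series, first, only, none or still open, it means among the compounds named here.

Compound 1 `COc1ccc(C(=O)c2cc(OC)c(OC)c(OC)c2)cc1NC(=O)/C=C/c1ccc(F)cc1` gives 3200 nM in a functional assay on PC-3 cells (Homo sapiens) for cytotoxicity, read by MTT assay, with a stated time of 72 h; on this read-out higher numbers stand for weaker inhibition and lower numbers for stronger inhibition. Compound 2 `COc1ccc(C(=O)c2cc(OC)c(OC)c(OC)c2)cc1NC(=O)/C=C/c1ccc(C(F)(F)F)cc1` carries the change (trifluoromethyl in place of fluoro on an aromatic carbon); in this assay compound 2 gives 3500 nM, the step being a 1.1-fold higher number from compound 1 to compound 2 (0.04 log units; within the scatter). Compound 3 `COc1cc(C(=O)c2cc(OC)c(OC)c(OC)c2)cc(NC(=O)/C=C/c2ccc(F)cc2)c1OC` differs from compound 1 in the core by methoxy in place of hydrogen on an aromatic carbon; in this assay compound 3 gives 4100 nM, a step of a 1.3-fold higher number from compound 1 to compound 3 (0.11 log units; within the scatter). All three numbers sit within the scatter of one another, so no order among them is claimed.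

Compound 4 `COc1cc(C(=O)c2cc(OC)c(OC)c(OC)c2)cc(NC(=O)/C=C/c2ccc(C(F)(F)F)cc2)c1OC` remains to be measured. It stands to compound 3 as compound 2 stands to compound 1: the change is trifluoromethyl in place of fluoro on an aromatic carbon, the same change at the same place. Among the measured compounds shown here, because the one precedent a 1.1-fold higher number from compound 1 to compound 2 (0.04 log units; within the scatter) lies within the scatter, a step of about a 1.1-fold higher number from compound 3 to compound 4 (0.04 log units; within the scatter) is expected from compound 3 to compound 4. Compound 4 is therefore estimated at 4500 nM in this assay, with a likely range of 2500 nM to 8000 nM.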

Compound 4, half-maximal inhibitory concentration: 4200 nM
Compound 4: the middle estimate sits 1.1-fold (0.03 log units) above what was measured; the range from low to high includes it.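

In this assay, trifluoromethyl in place of fluoro gives a 1.0-fold higher number from compound 3 to compound 4 (0.01 log units; within the scatter), and this step agrees with the one on the core of compound 1: the same change on two cores in this assay, a 1.1-fold higher number (0.04 log units; within the scatter) from compound 1 to compound 2 and a 1.0-fold higher number (0.01 log units; within the scatter) from compound 3 to compound 4, 1.1-fold (0.03 log units) apart, within the scatter of two such steps. Methoxy in place of hydrogen on an aromatic carbon gives a 1.2-fold higher number from compound 2 to compound 4 (0.08 log units; within the scatter), which likewise agrees with its earlier counterpart: the same change on two cores in this assay, a 1.3-fold higher number (0.11 log units; within the scatter) from compound 1 to compound 3 and a 1.2-fold higher number (0.08 log units; within the scatter) from compound 2 to compound 4, 1.1-fold (0.03 log units) apart, within the scatter of two such steps. Among the compounds shown here, both changes thus stay within the scatter on both cores, so the agreement shows only that neither change separates these four compounds, not that a step large enough to read would carry from one core to another.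

Still open, as far as these compounds go, is whether an amine or a carboxylic acid in place of the trifluoromethyl gives a step beyond the scatter. Whether such a step would hold on both cores is open too.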